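The source may report more compounds than this note shows. Statements on the series, on what has been measured and on what is new or still open speak of the compounds shown alone.

Compound 1, `COC(=O)C1=C(C)NC(c2nccs2)=NC1(C)c1ccc(F)cc1Cl`: 18 ug/mL
Compound 2, `COC(=O)C1=C(C)NC(c2nccs2)=NC1(C)c1ccc(S(C)(=O)=O)cc1`: 365 ug/mL
Compound 3, `COC(=O)C1=C(CN2CCOCC2=O)NC(c2nccs2)=NC1(C)c1ccc(F)cc1`: 440 ug/mL

Of the compounds shown here, three built on the same core have been measured in a physicochemical assay for solubility, read by HPLC, in phosphate buffer, at pH 6.5; on this read-out lower numbers stand for lower solubility and higher numbers for higher solubility. Compound 3 stands at the top of the three numbers, with 440 ug/mL. Compound 2 lies close by: in this assay compound 2 gives 365 ug/mL, a gap from compound 3 that falls within the usual scatter, so the two cannot be ordered against each other. Compound 1 is the outlier: in this assay compound 1 gives 18 ug/mL, a gap from compound 3 that lies beyond the scatter. Compounds 1 and 3 differ in more than one place, so their two values alone show the gap and nothing about its origin.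

Compound 4, `COC(=O)C1=C(COC(C(=O)O)C(F)(F)F)NC(c2nccs2)=NC1(C)c1ccc(F)cc1`, is the next step from compound 3. The change is a group of 9 heavy atoms (3 carbon, 3 oxygen, 3 fluorine; no ring) in place of a group of 7 heavy atoms (4 carbon, 1 nitrogen, 2 oxygen; one six-membered non-aromatic ring with 2 hetero atoms), on a saturated chain carbon bound to a double-bonded ring carbon. Among the compounds with values here, no pair of measured compounds differing in a single place is available, so the size of this step rests on the structures alone. A modest rise or a step lying within the scatter is expected, with a 1.1-fold higher number from compound 3 to compound 4 (0.06 log units; within the scatter) as the expected change. For compound 4 the estimate in this assay is 500 ug/mL, within 150 ug/mL to 1500 ug/mL.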

Compound 4, solubility: > 649 ug/mL
Compound 4: a limit, no number (the forecaster's own chance of this, stated with the estimate: 10%); middle value at least 1.2-fold (0.11 log units) from the limit.
By their numbers in this assay, from the lowest: compound 1; then compounds 2 and 3 (each within the scatter of the next). At a limit, above all of these: compound 4.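

In this assay compound 4 gives > 649 ug/mL, which is a limit of the assay and not a number. Within the data shown here, this is the first comparison between two compounds that differ in only one place: on a saturated chain carbon bound to a double-bonded ring carbon, replacing the 3-oxomorpholin-4-yl group with a ringless group gives an at least 1.4-fold higher number from compound 3 to compound 4 (0.16 log units; that floor lies within the scatter), so the true size of the step is unknown and only its floor is printed. The position therefore accepts a group with no ring and with a hydrogen-bond donor without the read-out dropping under that floor, and this one reading marks the top of the set: the limit of > 649 ug/mL in this assay, at which 1 of the 4 values shown sits.

With a single step at this position, nothing yet separates the contributions of the parts of the entering group, such as its trifluoromethyl and its carboxylic acid. Still open, from the compounds shown here alone, is how the read-out would respond to other groups at the same place, such as an amine, a longer chain, or the same chain without its fluorine atoms.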